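The compounds below may be only part of what the source reports. "The series", "measured", "known", "first", "only" and "open" are said of these compounds alone.

In an ADME assay on J774 cells (Mus musculus) for antiproliferative activity, with a stated time of 72 h (a lower number here means that less compound is needed, a higher number that more compound is needed for the effect), compound 1 `COC(=O)c1c[nH]c2cc(OC)c(Cl)cc2c1=O` gives 37000 nM and compound 2 `CCCCc1cc2c(=O)cc(C)[nH]c2cc1OCCOc1ccccc1` gives 28000 nM as its reading. These two numbers lie within the usual scatter of each other, so the data do not separate compound 2 from compound 1, although their structures differ in more than one place. Compound 3 `CCCCc1cc2c(=O)c(CC)c(C)[nH]c2cc1OCCOc1ccccc1` keeps the structure of compound 2 except for one change, (ethyl in place of hydrogen on an aromatic carbon), which is ethyl in place of hydrogen on an aromatic carbon. Among the compounds with values here, no measured pair differs in just one place, so nothing here shows directly how large such a step tends to be. Starting from compound 2 at 28000 nM as the only close reference, no change beyond the scatter is expected, with at most a slight drift towards a lower number. The estimated size is a step of a 1.4-fold lower number from compound 2 to compound 3 (0.15 log units; within the scatter) in all. For compound 3 the expected value is 20000 nM (estimated range 8000 nM to 50000 nM).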

Compound 3, half-maximal effective concentration: 1000 nM
The estimate for compound 3 lay 20-fold (1.30 log units) above the measured number; the measured number lies below the stated range.
By their numbers in this assay, from the lowest: compound 3; then compounds 2 and 1 (each within the scatter of the next).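

In this assay the swap of ethyl in place of hydrogen on this aromatic carbon, ortho to a methyl group and two atoms from the ring nitrogen, gives a 28-fold lower number from compound 2 to compound 3 (1.45 log units; beyond the scatter) and so lies beyond the scatter. Within the data shown here, this shows for the first time that the position is sensitive in this assay: ethyl adds no ring and no hydrogen-bond donors or acceptors, yet this one change produces a large step. Nothing available explains why the step is this large.

Among the compounds shown, ethyl is the only group at this carbon other than hydrogen, so it remains open whether a longer chain such as propyl, an amine or a carboxylic acid would give a similar step. As far as these compounds go, it also remains open whether ethyl would have the same effect on a different core.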